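This account rests on a few compounds, and the source may have more. Where it says the series, first, only, none or still open, it means among the compounds named here.

Among the compounds with values here, in an ADME assay on MDCK cells (Canis lupus familiaris) for cytotoxicity, read by microscopy, with a stated time of 72 h (a higher number here means that more compound is tolerated, a lower number that less compound is tolerated), compound 3 `COC(=O)C[C@H](NC(=O)OC(C)(C)C)C(=O)N(Cc1ccc([N+](=O)[O-])cc1)C1(C(=O)NCc2ccccc2)CCN(Cc2ccccc2)CC1` gives 20000 nM, the lowest of the three numbers measured so far. Compound 1 `COC(=O)C[C@H](NC(=O)OC(C)(C)C)C(=O)NC1(C(=O)NCc2ccccc2)CCN(Cc2ccccc2)CC1` gives 100000 nM and compound 2 `COC(=O)C[C@H](NC(=O)OC(C)(C)C)C(=O)N(C1CC1)C1(C(=O)NCc2ccccc2)CCN(Cc2ccccc2)CC1` gives 84000 nM; the step of a 1.2-fold lower number from compound 1 to compound 2 (0.08 log units; within the scatter) lies within the scatter, whereas a 5.0-fold lower number from compound 1 to compound 3 (0.70 log units; beyond the scatter) and a 4.2-fold lower number from compound 2 to compound 3 (0.62 log units; beyond the scatter) are both modest steps beyond it. Compound 4 `COC(=O)C[C@H](NC(=O)OC(C)(C)C)C(=O)N(Cc1ccc(Cl)cc1)C1(C(=O)NCc2ccccc2)CCN(Cc2ccccc2)CC1` differs from compound 3 in one place: chloro in place of nitro on an aromatic carbon. Within the data shown here, none of the measured steps alters a group on the six-membered aromatic ring of carbon only; the two steps that reach compound 3 both put the whole 4-nitrobenzyl group onto the amide-type nitrogen, and that benzyl group remains in compound 4 as 4-chlorobenzyl. They therefore give no direct guide to the size of this change, and with nothing in the data to move the number in either direction, the expected step of no change at the digits printed from compound 3 to compound 4 (within the scatter) is none beyond the scatter. Compound 4 is thus estimated at 20000 nM in this assay, with a range from 8000 nM to 50000 nM.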

Compound 4, minimum cytotoxic concentration: 100000 nM
The estimate for compound 4 lay 5.0-fold (0.70 log units) below the measured number, outside the stated range (above it).
By their numbers in this assay, from the lowest: compound 3; then compounds 2, 1 and 4 (each within the scatter of the next).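

Placing chloro in place of nitro on the aromatic carbon gives a 5.0-fold higher number from compound 3 to compound 4 (0.70 log units; beyond the scatter) in this assay, so the group at this place on the ring matters, which the earlier steps, all made on the amide-type nitrogen, could not show. The lower number of compound 3 therefore does not follow from a substituted benzyl group on that nitrogen as such: with 4-chlorobenzyl there the steps read a 1.2-fold higher number from compound 2 to compound 4 (0.08 log units; within the scatter) and no change at the digits printed from compound 1 to compound 4 (within the scatter), both within the scatter. Nothing available explains the difference between nitro and chloro here.

On these data alone, it remains open whether a plain hydrogen, fluoro, methoxy or an amine at this place would stand with chloro or with nitro. As far as these compounds go, it is also open whether nitro elsewhere on the ring would give the same number as in compound 3.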